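The source may hold more compounds than are shown below. What is called first, only, known or untested is meant among the compounds shown, and "the series" means these compounds.

Compound 2 `Cn1cnc(S(=O)(=O)N2C[C@@H]3[C@H](C2)[C@@]3(CNC(=O)c2c(Cl)cccc2Cl)CC2CC2)c1` is the starting point here. In an assay on isolated protein for inhibition of sodium- and chloride-dependent glycine transporter 1 (Homo sapiens) (on this read-out higher numbers stand for weaker inhibition and lower numbers for stronger inhibition), compound 2 gives 28 nM, which places it second highest among the three measured compounds: its nearest neighbour is compound 1 `Cn1cnc(S(=O)(=O)N2C[C@@H]3[C@H](C2)[C@@]3(CNC(=O)c2ccc(Cl)cc2Cl)CC2CC2)c1`, which gives 4 nM, and the furthest is compound 3 `CC(C)CS(=O)(=O)N1C[C@@H]2[C@H](C1)[C@@]2(CNC(=O)c1ccc(Cl)cc1Cl)CC1CC1`, which gives 2900 nM. The step of a 7.0-fold higher number from compound 1 to compound 2 (0.85 log units; beyond the scatter) shows how the aryl group on the carbonyl carbon shifts the number, while the step of a 730-fold higher number from compound 1 to compound 3 (2.86 log units; beyond the scatter) concerns the sulfonyl sulfur and does not bear on the change considered now.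

Compound 4 `Cn1cnc(S(=O)(=O)N2C[C@@H]3[C@H](C2)[C@@]3(CNC(=O)c2ccc(Cl)cc2)CC2CC2)c1` differs from compound 2 in one place: 4-chlorophenyl in place of 2,6-dichlorophenyl on a carbonyl carbon. Among the compounds with values here, the only measured step touching the same position is a 7.0-fold higher number from compound 1 to compound 2 (0.85 log units; beyond the scatter), a modest step; the 4-chlorophenyl group entering compound 4 resembles the 2,4-dichlorophenyl group of compound 1 more closely than the 2,6-dichlorophenyl group of compound 2, so the expected move is back toward the number of compound 1, without confidence that it is reached fully. The expected step is therefore a 2.8-fold lower number from compound 2 to compound 4 (0.45 log units; beyond the scatter), in the direction of stronger inhibition. On this basis compound 4 is estimated to give 10 nM in this assay, with a plausible range from 3 nM to 40 nM.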

Compound 4, half-maximal inhibitory concentration: 32 nM
Compound 4: the middle estimate sits 3.2-fold (0.51 log units) below what was measured; low and high end bracket the measured number.
By their numbers in this assay, from the lowest: compound 1; then compounds 2 and 4 (each within the scatter of the next); then compound 3.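

In this assay the change from 2,6-dichlorophenyl to 4-chlorophenyl on the carbonyl carbon comes out as a 1.1-fold higher number from compound 2 to compound 4 (0.06 log units; within the scatter), so these two groups cannot be told apart on this read-out, even though one carries a chloro group more than the other. The more telling comparison is with compound 1, where hydrogen in place of chloro on an aromatic carbon, turning 2,4-dichlorophenyl into 4-chlorophenyl, gives an 8.0-fold higher number from compound 1 to compound 4 (0.90 log units; beyond the scatter), so that single chloro group separates compound 1 from compound 4, and of the three aryl groups shown at this position only 2,4-dichlorophenyl stands apart. No data are at hand to explain why that one chloro group counts for so much when the chloro count alone does not follow the numbers.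

The compounds shown leave open whether chloro itself is needed at that place or whether fluoro, methyl or methoxy would serve as well, and where a plain phenyl group would fall. They also leave open whether the same step would appear with isobutyl on the sulfonyl sulfur, as in compound 3, in place of 1-methyl-1H-imidazol-4-yl.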